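A few compounds are considered here, and "the series" means these few. Any claim that something is new, unique, unknown or untested is made for them only; others in the source may bear on it.

Two compounds carry the shared core of compound 1 `COc1cc(Oc2cccc(Nc3ccccc3)c2)cc(OC)c1CNCc1ccc(F)cc1` with a different group on the amine nitrogen. In a functional assay on SW-620 cells (Homo sapiens) for inhibition, read by MTT assay, with a stated time of 72 h (a lower number here means a stronger inhibitor, a higher number a weaker inhibitor), compound 1 gives 6770 nM. Compound 2 `COc1ccc(CCCNCc2c(OC)cc(Oc3cccc(Nc4ccccc4)c3)cc2OC)cc1` carries a longer chain ending in a methoxy-bearing ring, and in this assay compound 2 gives 6400 nM. Among the measured compounds shown here, the only step measured so far is a 1.1-fold lower number from compound 1 to compound 2 (0.02 log units; within the scatter), so compound 2 and compound 1 sit within the scatter of each other and neither can be called the stronger.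

Compound 3 `COc1cc(Oc2cccc(Nc3ccccc3)c2)cc(OC)c1CN(C)C` is the next compound. Its change is dimethylamino in place of (3-(4-methoxyphenyl)propyl)amino on a saturated chain carbon bound to an aromatic carbon. This differs in kind from the measured step: there, one ring-bearing group on the amine replaced another and nothing moved; here the ring and its chain are removed altogether and the nitrogen is left with two methyl groups. For the measured compounds named here, no measured step shows what losing the ring does, so the expectation rests only on the observation that changing the amine substituent left the number essentially unchanged. Compound 3 is therefore expected to land near compound 2, with a wide range, a step of a 1.3-fold higher number from compound 2 to compound 3 (0.12 log units; within the scatter), giving an estimate of 8500 nM between 3000 nM and 25000 nM.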

Compound 3, half-maximal inhibitory concentration: > 20000 nM
Compound 3 ended at the assay's limit; the forecaster's own chance of this, stated with the estimate: 10%; middle value at least 2.3-fold (0.37 log units) from the limit.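

In this assay compound 3 gives > 20000 nM, which is a limit of the assay and not a number: the limit of > 20000 nM in this assay, at which 1 of the 3 values shown sits. Exchanging one ring-bearing group for another on the amine nitrogen left the number where it was, but replacing (3-(4-methoxyphenyl)propyl)amino with dimethylamino gives an at least 3.1-fold higher number from compound 2 to compound 3 (0.49 log units; beyond the scatter), and replacing (4-fluorobenzyl)amino with dimethylamino gives an at least 2.9-fold higher number from compound 1 to compound 3 (0.47 log units; beyond the scatter). So this position is not indifferent to what it carries: both compounds with a ring-bearing amine are stronger inhibitors than compound 3, and the tolerance seen in the first step holds only among those ring-bearing groups.

The change to dimethylamino removes several things at once, the six-membered aromatic ring, most of the heavy atoms and the hydrogen-bond donor, and the compounds shown cannot say which of these losses matters. A methylamino group would keep the donor while staying small, a hexylamino group would keep a longer chain without any ring, and a cyclohexylmethylamino group would keep a ring that is not aromatic, so each would separate these losses from one another.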